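Swapping a Bromide for an Azide on a Tolerated Core

The source may hold more compounds than are shown below. What is called first, only, known or untested is meant among the compounds shown, and "the series" means these compounds.

Compound 1 `BrCCCCc1ccc(-c2ccc(-c3ccc(-c4cccs4)s3)s2)s1` carries a 4-bromobutyl chain at one end of its shared core, while compound 2 `BrCCCCc1ccc(-c2ccc(-c3ccc(CCCCBr)s3)s2)s1` carries that same chain at both ends. In an ADME assay on MDCK cells (Canis lupus familiaris) for cytotoxicity, read by MTT assay, with a stated time of 2 days (a higher number here means that more compound is tolerated, a lower number that less compound is tolerated), compound 1 is reported as "not determined" (no result reported), with no result of its own. Compound 2 gives > 200000 nM in this assay, and this is a limit of the measurement rather than a number. Within the data shown here, compound 1 therefore stands without a single number, and the only related value is that limit, (the limit of > 200000 nM in this assay, at which 1 of the 2 values shown sits).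

Compound 3 `[N-]=[N+]=NCCCc1ccc(-c2ccc(-c3ccc(-c4cccs4)s3)s2)s1` is still to be measured in this assay. It differs from compound 1 in one place: azido in place of bromomethyl on a saturated chain carbon, three bonds along the chain from an aromatic carbon. Among the measured compounds shown here, no pair of measured compounds shows what this swap does, so there is no measured step to lean on. Since compound 2 gives > 200000 nM in this assay, the expected step from compound 1 to compound 3 is none beyond the usual scatter, in either direction. Compound 3 is expected to give about 200000 nM in this assay, within a range from 100000 nM to 400000 nM, most likely again reported only as a limit.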

Compound 3, half-maximal cytotoxic concentration: > 100000 nM
Compound 3: a limit, no number; the forecaster's own chance of this, stated with the estimate: 80%; the middle value lies beyond the limit too.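

Compound 3 gives > 100000 nM in this assay, and this is a limit, not a number. Among these compounds, compound 1 has no result, so no step from compound 1 to compound 3 can be read. The compounds shown leave open whether, and at what concentration, any of them harms these cells, and what swapping bromomethyl for azido does to that concentration.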